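Shortening the chain on compound 2: propyl to methyl

This account rests on a few compounds, and the source may have more. Where it says the series, first, only, none or still open, it means among the compounds named here.

Measured so far:
- Compound 1, `CCCn1c(-c2ccccc2)nc2c(NC3CCCC3)ncnc21`: 749 nM
- Compound 2, `CCCn1c(-c2ccccc2)nc2c(NC3CCOC3)ncnc21`: 2810 nM

Both compounds were tested in an assay on CHO cells for displacement of a labelled ligand from adenosine receptor A3 (Homo sapiens), read by scintillation counting, with a stated time of 3 h; on this read-out lower numbers stand for stronger inhibition and higher numbers for weaker inhibition. Compound 2 gives the higher of the two numbers; its nearest neighbour is compound 1, and the step of a 3.8-fold higher number from compound 1 to compound 2 (0.57 log units; beyond the scatter) lies beyond the usual scatter of such measurements.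

Compound 3, `Cn1c(-c2ccccc2)nc2c(NC3CCOC3)ncnc21`, has not yet been measured. It differs from compound 2 in one place: hydrogen in place of ethyl on a saturated chain carbon bound to an aromatic nitrogen. Among the measured compounds shown here, the earlier step exchanged the ring on the amine nitrogen, and no measured step touches the chain on the aromatic nitrogen, so there is no direct guide to how this change will read. For the measured compounds named here, the only available comparison, the step from compound 1 to compound 2, shows how far a single change at another place moved the number, and it is treated here as a measure of the scale of single changes rather than of their direction. For compound 3 a modest rise in the number is expected, a 1.6-fold higher number from compound 2 to compound 3 (0.20 log units; within the scatter), with wide uncertainty. The estimate for compound 3 is therefore 4500 nM, with a range from 1500 nM to 15000 nM.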

Compound 3, inhibition constant: 6260 nM
Beside the measured number, compound 3's estimate is 1.4-fold (0.14 log units) below it, within the range that was stated.
By their numbers in this assay, from the lowest: compound 1; then compound 2; then compound 3.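

Among the compounds shown here, this is the first look at the chain on the aromatic nitrogen, and in this assay shortening it from propyl to methyl gives a 2.2-fold higher number from compound 2 to compound 3 (0.35 log units; beyond the scatter) and so shows that this position is not indifferent to what it carries. For this pair, which shares the oxolan-3-yl group on the amine nitrogen, the longer chain goes with the lower number, and the earlier change on that nitrogen, a 3.8-fold higher number from compound 1 to compound 2 (0.57 log units; beyond the scatter) also moved the number upward, so single changes at two separate places have now shifted the read-out beyond the usual scatter. The data show the size and direction of this step but offer no measurement that would explain it.

Going by these compounds, it remains open whether lengthening the chain past propyl, to butyl or pentyl, would bring the number down further, and whether a chain ending in an amine or a carboxylic acid would be tolerated at this position. On these data alone, it is also open whether going from propyl to methyl would move the number by a similar amount with cyclopentyl in place of oxolan-3-yl on the amine nitrogen.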